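The source may report more compounds than this note shows. Statements on the series, on what has been measured and on what is new or still open speak of the compounds shown alone.

In a functional assay on HEL cells (Homo sapiens) for inhibition, read by MTT assay, with a stated time of 48 h (on this read-out lower numbers stand for stronger inhibition and higher numbers for weaker inhibition), compound 1 `O=S(=O)(c1ccccc1)c1c(OCCCCCCO)no[n+]1[O-]` gives 2160 nM, while compound 2 `O=C(CCCCCCCOc1no[n+]([O-])c1S(=O)(=O)c1ccccc1)NO` gives 10800 nM, the higher of the two numbers and so the weaker inhibition. Compound 3 `O=C(COCCOc1no[n+]([O-])c1S(=O)(=O)c1ccccc1)NO` differs from compound 2 in one place: (hydroxycarbamoyl)methoxy in place of 5-(hydroxycarbamoyl)pentyl on a saturated chain carbon, two bonds along the chain from an oxygen on an aromatic ring. For the measured compounds named here, only one measured step bears on this, a modest one: a 5.0-fold higher number from compound 1 to compound 2 (0.70 log units; beyond the scatter). Going by the values given here, compound 3 still carries the hydroxycarbamoyl group, and no measured step tests this change of chain, so no shift beyond the scatter is expected, in either direction. The expected change is a 1.2-fold lower number from compound 2 to compound 3 (0.08 log units; within the scatter). For compound 3 the estimated value is 9000 nM, within a range of 3000 nM to 27000 nM.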

Compound 3, half-maximal inhibitory concentration: 6790 nM
Compound 3: the middle estimate sits 1.3-fold (0.12 log units) above what was measured; the measured number falls inside the stated range.
By their numbers in this assay, from the lowest: compound 1; then compounds 3 and 2 (each within the scatter of the next).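

Replacing 5-(hydroxycarbamoyl)pentyl with (hydroxycarbamoyl)methoxy, which puts an oxygen into the chain, does not move the number beyond the scatter (a 1.6-fold lower number from compound 2 to compound 3 (0.20 log units; within the scatter)). At this place on the chain, then, this change is tolerated, while compound 1 with its plain hydroxy chain end still gives the lowest number (a 3.1-fold higher number from compound 1 to compound 3 (0.50 log units; beyond the scatter)). Nothing available here explains either result.

From the compounds shown here alone, what a carboxylic acid in place of the hydroxycarbamoyl group would give remains open. So does the effect of a longer chain containing an oxygen, as compound 3 does.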